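Swapping fluoro for trifluoromethyl in a series at the limit

The compounds below may be only part of what the source reports. "The series", "measured", "known", "first", "only" and "open" are said of these compounds alone.

Of the compounds shown here, three sharing one core have been tested in a functional assay on SMMC-7721 cells (Homo sapiens) for cytotoxicity, read by MTT assay, with a stated time of 4 days; a higher number here means a weaker inhibitor, a lower number a stronger inhibitor. Compound 1 `C=C1C[C@]23C[C@@]1(O)CC[C@H]2c1ccc(OS(=O)(=O)c2ccc(C)cc2)c(C)c1[C@@H]3Cn1cc(-c2ccc(Br)cc2)nn1` carries a bromo group on a six-membered aromatic ring of carbon only. In this assay compound 1 gives only a limit of the assay, > 20000 nM, and not a number. Compound 2 `C=C1C[C@]23C[C@@]1(O)CC[C@H]2c1ccc(OS(=O)(=O)c2ccc(C)cc2)c(C)c1[C@@H]3Cn1cc(-c2ccc(C)cc2)nn1` carries methyl in place of that bromo. In this assay compound 2 likewise gives only a limit, > 20000 nM. Compound 3 `C=C1C[C@]23C[C@@]1(O)CC[C@H]2c1ccc(OS(=O)(=O)c2ccc(C)cc2)c(C)c1[C@@H]3Cn1cc(-c2ccc(F)cc2)nn1` carries fluoro in that place. In this assay compound 3 also gives only a limit, > 20000 nM. Because all three sit at the limit of > 20000 nM in this assay, at which 3 of the 3 values shown sit, the steps among them cannot be read: a step that the two limits leave unreadable from compound 1 to compound 2, a step that the two limits leave unreadable from compound 1 to compound 3 and a step that the two limits leave unreadable from compound 2 to compound 3. Compound 3 therefore stands exactly where its two companions stand, at the edge of what this assay can report.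

Compound 4 `C=C1C[C@]23C[C@@]1(O)CC[C@H]2c1ccc(OS(=O)(=O)c2ccc(C)cc2)c(C)c1[C@@H]3Cn1cc(-c2ccc(C(F)(F)F)cc2)nn1` differs from compound 3 by a single change: trifluoromethyl in place of fluoro on an aromatic carbon. The three measured steps, all unreadable, bear on this swap only in that exchanging bromo, methyl and fluoro at that place never brought any compound into the measurable range. No step beyond the scatter is expected, and the estimated step that the limit leaves unreadable from compound 3 to compound 4 is set near zero. Compound 4 is therefore expected to give about 30000 nM, within a range from 10000 nM to 100000 nM, most likely again as a limit rather than a number.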

Compound 4, half-maximal inhibitory concentration: > 20000 nM
Compound 4: only a limit was reported (the forecaster's own chance of this, stated with the estimate: 80%); the middle value does not contradict the limit.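

Compound 4 gives only a limit of the assay, > 20000 nM, and not a number. No step between compound 4 and compound 1, compound 2 or compound 3 can be read in this assay, because all four sit at the same edge: the limit of > 20000 nM in this assay, at which 4 of the 4 values shown sit.

The compounds shown leave open how strongly, if at all, any of the four acts on these cells, and whether any other group at this place would give a measurable value.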